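The compounds below may be only part of what the source reports. "The series", "measured", "known", "first", "only" and "open" are said of these compounds alone.

The measured compounds: compound 1 `CCCS(=O)(=O)Nc1cccc2c1CCC2c1ncc[nH]1` gives 54%; compound 2 `Cc1c(OCC2=NCCN2)ccc(Cl)c1NS(C)(=O)=O` gives 60%; compound 3 `Cc1oncc1-c1cccc2c1CCC2c1ncc[nH]1` gives 63%.

These values come from a functional assay on CHO cells for agonist activity at Alpha-1A adrenergic receptor (Homo sapiens), read by FLIPR and calcium flux; on this read-out higher numbers stand for larger maximal responses and lower numbers for smaller maximal responses. On these numbers compound 1 has the smallest value of the three, but neither compound 2 nor compound 3 is separated from it beyond the usual scatter, so the three are not ordered with any confidence.

Compound 4 `c1ccc2c(c1)CCC2c1ncc[nH]1` differs from compound 1 in one place: hydrogen in place of (propylsulfonyl)amino on an aromatic carbon. For the measured compounds named here, the only measured step at this position is a number 9 percentage points higher from compound 1 to compound 3 (within the scatter), where a 5-methyl-1,2-oxazol-4-yl stood in place of the (propylsulfonyl)amino group; that step stayed within the scatter. Nothing measured shows the bare core without a group on that aromatic carbon. Given that the one exchange at this position in this assay moved nothing beyond the scatter, the expected step of a number 1 percentage points higher from compound 1 to compound 4 (within the scatter) is likewise small, with no direction claimed beyond the scatter. Compound 4 is therefore estimated at 55% in this assay, within a range of 30% to 80%.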

Compound 4, largest response reached (Emax), in percent of the reference or control that the assay uses: 54%
Compound 4: middle estimate off by 1 percentage points, on the high side, and the stated range covers the measured number.
By their numbers in this assay, from the lowest: compounds 1, 4, 2 and 3 (each within the scatter of the next).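

With hydrogen on this aromatic carbon, the record reads no change at the digits printed from compound 1 to compound 4 (within the scatter) and a number 9 percentage points lower from compound 3 to compound 4 (within the scatter) in this assay, so the bare core can now be set against both substituted compounds. For the compounds shown here, neither the (propylsulfonyl)amino group nor the 5-methyl-1,2-oxazol-4-yl group is separated from hydrogen on this read-out, which the single earlier exchange between those two groups could not show. No measurement offered here explains this outcome.

As far as these compounds go, it remains open whether a different group at this place, such as an amine, a carboxylic acid or a longer alkyl chain, would move the maximal response beyond the scatter. The compounds shown also leave open whether hydrogen would be equally tolerated on the other aromatic carbons of the six-membered ring.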